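The source may hold more compounds than are shown below. What is called first, only, known or untested is meant among the compounds shown, and "the series" means these compounds.

The account follows a single change made to compound 1 `O=C(CSc1ncccn1)N/N=c1/scc(-c2ccc(Br)cc2)n1-c1ccccc1`. In a functional assay on C6 cells (Rattus norvegicus) for cytotoxicity, read by MTT assay, with a stated time of 24 h (on this read-out lower numbers stand for stronger inhibition and higher numbers for weaker inhibition), compound 1 gives > 200 ug/mL, which is a limit of the assay rather than a measured number. Two companions share the same core. Compound 2 `Cn1cnnc1SCC(=O)N/N=c1/scc(-c2ccc(C#N)cc2)n1-c1ccccc1` also reaches only a limit in this assay, with a value of > 200 ug/mL. For compound 3 `Cn1cnnc1SCC(=O)N/N=c1/scc(-c2ccc(Br)cc2)n1-c1ccccc1` this assay reports "not determined" (no result reported), so no number exists for it. Compound 1 therefore stands without a single number of its own, next to one further limit and one entry with no result; the only firm point in the set is the limit of > 200 ug/mL in this assay, at which 2 of the 3 values shown sit.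

The new compound is compound 4 `Cc1ccc(-c2cs/c(=N/NC(=O)CSc3ncccn3)n2-c2ccccc2)cc1`. It differs from compound 1 by methyl in place of bromo on an aromatic carbon, the 4-bromophenyl of compound 1 becoming a 4-methylphenyl in compound 4. Among the compounds with values here, no step between measured compounds is available to calibrate this change, and with only a limit for compound 1 there is no measured activity from which a shift could be resolved. The expected step is therefore none beyond the scatter, a step that the limit leaves unreadable from compound 1 to compound 4. Compound 4 is accordingly expected to give about 250 ug/mL in this assay, within a range from 120 ug/mL to 600 ug/mL, and most likely to be reported again only as a limit.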

Compound 4, half-maximal inhibitory concentration: 85 ug/mL
Compound 4: middle estimate off by 2.9-fold (0.47 log units), on the high side; the measured number lies below the stated range.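

Compound 4 gives the set its first firm number: in this assay compound 4 gives 85 ug/mL, a measured value rather than a limit. Methyl in place of bromo on an aromatic carbon, para to a large group, produces an at least 2.3-fold lower number from compound 1 to compound 4 (0.37 log units; beyond the scatter), so this one exchange on the 4-bromophenyl, with no change in ring or in the count of hydrogen-bond donors or acceptors, is enough to bring a compound into the measurable range of the assay. The step has a lower bound only, and compound 4 now stands apart from the other entries that carry a sign rather than a number: the limit of > 200 ug/mL in this assay, at which 2 of the 4 values shown sit.

The compounds shown leave open whether the lower number belongs to methyl in particular or would also appear with another group at this place, such as a methoxy group, an amine or a longer chain such as ethyl. They also leave open whether the same exchange would have a comparable effect on the different side chain carried by compound 2 and compound 3.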